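The source may report more compounds than this note shows. Statements on the series, on what has been measured and on what is new or still open speak of the compounds shown alone.

Measured so far in an ADME assay on microsomes from liver (Mus musculus) for metabolic stability, read by LC-MS, with a stated time of 30 min, tested at 1 uM; on this read-out lower numbers stand for a less stable compound and higher numbers for a more stable compound:
compound 1, `O=C(NCc1ccc(S(=O)(=O)c2cc(F)cc(F)c2)cc1)c1cc2ccncc2o1`: 12%
compound 2, `O=C(NCc1ccc(S(=O)(=O)c2cc(F)cc(F)c2)cc1)c1cc2cnccc2[nH]1`: 63%
compound 3, `CC(NC(=O)c1cc2cnccc2[nH]1)c1ccc(S(=O)(=O)N2CCCCC2)cc1`: 0.65%

Compound 1 stands second highest of the three numbers. Compound 2 sits well above it, the step being a number 51 percentage points higher from compound 1 to compound 2 (beyond the scatter). Within the data shown here, compound 3 gives 0.65%, a value below that of compound 1 and beyond the scatter; compound 3 differs from compound 1 in more than one place, so no single step is drawn between them.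

Compound 4, `O=C(NCc1ccc(S(=O)(=O)c2cccc(C(F)(F)F)c2)cc1)c1cc2ccncc2o1`, is not yet measured. It differs from compound 1 in one place: 3-(trifluoromethyl)phenyl in place of 3,5-difluorophenyl on a sulfonyl sulfur.

Among the measured compounds shown here, none of the measured steps bears on this change. For the measured compounds named here, the one step available, from compound 1 to compound 2, concerns the group on the carbonyl carbon, not the group on the sulfonyl sulfur, and it is large. The pair compound 1 and compound 3 alters the sulfonyl substituent together with other parts of the molecule, so nothing can be read from it about the sulfonyl side alone. Going by the values given here, with no comparable step in hand, no direction can be assigned to the change, and the expectation in this assay is a step of no change at the digits printed from compound 1 to compound 4 (within the scatter), that is, none beyond the scatter. Compound 4 is therefore estimated at 12%, with a range from 3% to 30%.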

Compound 4, percent of the compound remaining: 64%
Compound 4: the middle estimate sits 52 percentage points below what was measured; measured number above the stated range.
By their numbers in this assay, from the lowest: compound 3; then compound 1; then compounds 2 and 4 (each within the scatter of the next).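

In this assay, the group on the sulfonyl sulfur proves able to move the read-out on its own: with the rest of compound 1 held fixed, 3-(trifluoromethyl)phenyl in place of 3,5-difluorophenyl gives a number 52 percentage points higher from compound 1 to compound 4 (beyond the scatter), a step of large size. Among these compounds, the earlier compounds offered one readable step, on the carbonyl carbon, so this is the first sign that a second place also carries a large change in the percent of compound remaining. No measurement at hand accounts for this step, which stands here as an observation without an explanation.

The exchange removes two fluorine atoms and brings in a trifluoromethyl group in a single step, and the compounds shown do not separate these two parts, as they include neither plain phenyl, 3-fluorophenyl nor 3-chlorophenyl on the sulfonyl sulfur. Also open, on these data alone, is whether 3-(trifluoromethyl)phenyl gives a similar step on the core of compound 2, and how a nitrile or a methoxy group on that phenyl ring would compare.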